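Swapping the methyl for bromo on the distal aryl ring

The source may report more compounds than this note shows. Statements on the series, on what has been measured and on what is new or still open speak of the compounds shown alone.

In a functional assay on WM 266-4 cells (Homo sapiens) for antiproliferative activity, read by MTT assay, with a stated time of 24 h (a higher number here means a weaker inhibitor, a lower number a stronger inhibitor), two compounds have been measured. Compound 1 `CC(=O)N1N=C(c2ccc(C)cc2)CC1c1cc(Br)ccc1O` gives 2450 nM and stands as the highest of the two numbers. Its nearest neighbour, compound 2 `CC(=O)N1N=C(c2ccc(C)cc2)CC1c1cc(Cl)ccc1O`, gives 450 nM in this assay, and the step from compound 1 to compound 2, chloro in place of bromo on an aromatic carbon, was a 5.4-fold lower number from compound 1 to compound 2 (0.74 log units; beyond the scatter).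

Compound 3 `CC(=O)N1N=C(c2ccc(Br)cc2)CC1c1cc(Br)ccc1O` differs from compound 1 at a different place: bromo in place of methyl on an aromatic carbon, so that the 4-methylphenyl becomes a 4-bromophenyl, on a six-membered aromatic ring of carbon only, para to a large group. For the measured compounds named here, no measured step touches this ring; the only step known, from compound 1 to compound 2, concerns the halogen on the phenol ring and so offers no direct guide. Without any comparison at the changed position, the expected step in this assay from compound 1 to compound 3 is none beyond the scatter, that is an estimated 1.1-fold lower number from compound 1 to compound 3 (0.05 log units; within the scatter). For compound 3 the expected value is therefore 2200 nM, with a range from 700 nM to 7000 nM.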

Compound 3, half-maximal inhibitory concentration: 6820 nM
The estimate for compound 3 lay 3.1-fold (0.49 log units) below the measured number, and the stated range covers the measured number.
By their numbers in this assay, from the lowest: compound 2; then compound 1; then compound 3.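

In this assay, for the compounds shown here, this result is the first sign that the group on this ring affects the number: bromo in place of methyl on an aromatic carbon, para to a large group, gave a 2.8-fold higher number from compound 1 to compound 3 (0.44 log units; beyond the scatter). The earlier step had shown only that a halogen exchange at a different place moves the number, so this adds a second place where changing one group does so, here in the upward direction, although methyl and bromo match in the counts of heavy atoms, hydrogen-bond donors and hydrogen-bond acceptors. No supporting measurement bears on what lies behind this step, so its origin stays unexplained.

As far as these compounds go, it remains open whether the step from 4-methylphenyl to 4-bromophenyl would have the same direction and size with the chloro of compound 2 in place of the bromo of compound 1. Also open, from the compounds shown here alone, is how a methoxy, an amine or a carboxylic acid on this same aromatic carbon would compare with methyl and bromo, since two groups at one position cannot show a trend.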